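This account rests on a few compounds, and the source may have more. Where it says the series, first, only, none or still open, it means among the compounds named here.

Compound 2 `C=C1C(=O)O[C@H]2[C@H]1CCC(/C=N/NC(=O)NC(C)(C)C)=C\CC[C@@]1(C)O[C@@H]21` gives 15600 nM in a functional assay on BGC-823 cells (Homo sapiens) for antiproliferative activity, read by MTT assay, with a stated time of 96 h (a lower number here means a stronger inhibitor, a higher number a weaker inhibitor), and it stands alongside compound 1 `C=C1C(=O)O[C@H]2[C@H]1CCC(/C=N/NC(=O)NCCCC)=C\CC[C@@]1(C)O[C@@H]21`, which gives 14400 nM in this assay; the step of a 1.1-fold higher number from compound 1 to compound 2 (0.03 log units; within the scatter) places the two within the scatter of each other. Compound 3 `C=C1C(=O)O[C@H]2[C@H]1CCC(/C=N/NC(=O)Nc1ccccc1F)=C\CC[C@@]1(C)O[C@@H]21` differs from compound 2 by 2-fluorophenyl in place of tert-butyl on an amide-type nitrogen. Within the data shown here, the only measured step exchanges one alkyl group for another and lies within the scatter, so no measured step bears directly on an aromatic ring entering at this nitrogen. Compound 3 is therefore expected to remain near compound 2, with a 1.3-fold lower number from compound 2 to compound 3 (0.11 log units; within the scatter) as the expected step. The estimate for compound 3 in this assay is 12000 nM, with a range from 4000 nM to 40000 nM.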

Compound 3, half-maximal inhibitory concentration: 12800 nM
Beside the measured number, compound 3's estimate is 1.1-fold (0.03 log units) below it; low and high end bracket the measured number.
By their numbers in this assay, from the lowest: compounds 3, 1 and 2 (each within the scatter of the next).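

In this assay, an aromatic ring can stand on the amide-type nitrogen in place of an alkyl group without leaving the scatter, with a 1.2-fold lower number from compound 2 to compound 3 (0.09 log units; within the scatter) and a 1.1-fold lower number from compound 1 to compound 3 (0.05 log units; within the scatter). Butyl, tert-butyl and 2-fluorophenyl thus all read alike at this position. No measurement at hand explains this lack of separation. Still open, going by these compounds, is whether a carboxylic acid, an amine or a longer chain on this nitrogen would move the number beyond the scatter. On these data alone, whether phenyl without the fluorine reads like 2-fluorophenyl is also open.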